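Hydroxyphenyl placement in a symmetric diaryl pyridine series

This account rests on a few compounds, and the source may have more. Where it says the series, first, only, none or still open, it means among the compounds named here.

Compound 1 `Oc1cccc(-c2cc(-c3ccsc3)cc(-c3cccc(O)c3)n2)c1` gives 16600 nM in a functional assay on HeLa cells (Homo sapiens) for cytotoxicity, read by CCK-8 assay; on this read-out higher numbers stand for weaker inhibition and lower numbers for stronger inhibition. Compound 2 `Oc1ccc(-c2cc(-c3ccsc3)cc(-c3cccc(O)c3)n2)cc1` gives 2580 nM in this assay; the step of a 6.4-fold lower number from compound 1 to compound 2 (0.81 log units; beyond the scatter) follows the change (4-hydroxyphenyl in place of 3-hydroxyphenyl on an aromatic carbon). Compound 3 `Oc1ccc(-c2cc(-c3ccccn3)cc(-c3cccc(O)c3)n2)cc1` gives 1930 nM in this assay, and the step of a 1.3-fold lower number from compound 2 to compound 3 (0.13 log units; within the scatter) lies within scatter. The difference between the cores of compound 1 and compound 3 is not broken down here. Compound 4 `Oc1ccc(-c2cc(-c3ccccn3)cc(-c3ccc(O)cc3)n2)cc1` is not yet measured; it differs from compound 3 by 4-hydroxyphenyl in place of 3-hydroxyphenyl on an aromatic carbon. This is the same kind of change as from compound 1 to compound 2, but the place differs: there it was meta to a 3-hydroxyphenyl group and meta to a thiophen-3-yl group, here meta to a 4-hydroxyphenyl group and meta to a pyridin-2-yl group. Because the earlier step of a 6.4-fold lower number from compound 1 to compound 2 (0.81 log units; beyond the scatter) was modest, compound 4 is expected to show a smaller step of a 2.8-fold lower number from compound 3 to compound 4 (0.44 log units; beyond the scatter) in this assay. The estimate for compound 4 in this assay is 700 nM, expected to fall between 300 nM and 1900 nM.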

Compound 4, half-maximal inhibitory concentration: > 50000 nM
Compound 4 gave a limit, no number; the forecaster's own chance of this, stated with the estimate: 0%; middle value at least 71-fold (1.85 log units) away from the limit.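

In this assay the change to 4-hydroxyphenyl does not carry over from one core to the other, and here it gives an at least 25-fold higher number from compound 3 to compound 4 (1.41 log units; beyond the scatter), opposite in direction to the earlier step: the same change on two cores in this assay, a 6.4-fold lower number (0.81 log units; beyond the scatter) from compound 1 to compound 2 and an at least 25-fold higher number (1.41 log units; beyond the scatter) from compound 3 to compound 4, at least 160-fold (2.22 log units) apart, beyond the scatter of two such steps. For compound 4 the read-out is > 50000 nM, a limit of the assay and not a number, so the size of this step is bounded on one side only. The two steps do not show which difference between the cores, pyridin-2-yl for thiophen-3-yl or the 4-hydroxyphenyl group already present, goes with the reversal, and they give no rule for other cores.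

Going by these compounds, how the thiophen-3-yl core reads with two 4-hydroxyphenyl groups remains open. So does the effect of a methoxyphenyl or aminophenyl group in place of 4-hydroxyphenyl.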